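Three Close Values and a 2-Chloropyridin-3-yl Swap

The source may report more compounds than this note shows. Statements on the series, on what has been measured and on what is new or still open speak of the compounds shown alone.

In an ADME assay on MT4 cells (Homo sapiens) for cytotoxicity, read by MTT assay (a lower number here means that less compound is tolerated, a higher number that more compound is tolerated), three compounds with a shared core lie close together. Compound 1 (`O=C(CSc1nncnc1-c1cccc2ccccc12)Nc1ccccc1[N+](=O)[O-]`) gives 142000 nM there, compound 2 (`O=C(CSc1nncnc1-c1cccc2ccccc12)Nc1ccc(Cl)cc1Cl`) gives 254000 nM there, and compound 3 (`O=C(CSc1nncnc1-c1cccc2ccccc12)Nc1ccccc1`) gives 154000 nM there. Compound 3 has no clear rank among them: its gaps to both others stay within the scatter.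

The next compound, compound 4 (`O=C(CSc1nncnc1-c1cccc2ccccc12)Nc1cccnc1Cl`), has 2-chloropyridin-3-yl in place of phenyl on an amide-type nitrogen. Three measured steps also changed the ring on that nitrogen, giving a 1.8-fold higher number from compound 1 to compound 2 (0.25 log units; within the scatter) and a 1.1-fold higher number from compound 1 to compound 3 (0.04 log units; within the scatter) and also a 1.6-fold lower number from compound 2 to compound 3 (0.22 log units; within the scatter) with none beyond the scatter. Within the data shown here, no measured compound carries a ring with a hetero atom there, so that part of the change remains untested. The expected step is therefore small, a 1.1-fold higher number from compound 3 to compound 4 (0.04 log units; within the scatter) and no larger than the scatter. For compound 4 the estimated value in this assay is 170000 nM with an expected range from 90000 nM to 300000 nM in this read-out.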

Compound 4, half-maximal cytotoxic concentration: 44000 nM
Compound 4: the middle estimate sits 3.9-fold (0.59 log units) above what was measured, and the stated range ends above it.
By their numbers in this assay, from the lowest: compound 4; then compounds 1, 3 and 2 (each within the scatter of the next).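

In this assay this amide-type nitrogen proves sensitive to its ring: the three earlier rings stayed within the scatter of one another, yet 2-chloropyridin-3-yl falls clear of phenyl (a 3.5-fold lower number from compound 3 to compound 4 (0.54 log units; beyond the scatter)) and of 2,4-dichlorophenyl (a 5.8-fold lower number from compound 2 to compound 4 (0.76 log units; beyond the scatter)) and of 2-nitrophenyl (a 3.2-fold lower number from compound 1 to compound 4 (0.51 log units; beyond the scatter)). A lower number here means that less compound is tolerated, so compound 4 is the least tolerated of the four, with its steps to all the others beyond the scatter. No supporting measurement bears on what lies behind this drop.

The swap brings in a ring nitrogen and a chlorine together, so the compounds shown cannot separate the two, which plain pyridin-3-yl and 2-chlorophenyl would do. Also open, on these data alone, is whether the drop would persist with a methyl or an amine in place of that chlorine.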